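The source may report more compounds than this note shows. Statements on the series, on what has been measured and on what is new or still open speak of the compounds shown alone.

Working notes on the series, read in a functional assay on PC-3 cells (Homo sapiens) for inhibition, read by sulforhodamine B assay, with a stated time of 48 h; a lower number here means a stronger inhibitor of growth, a higher number a weaker inhibitor of growth. Compound 1 (`CCOC(=O)c1nn(-c2ccccc2)c(-c2ccc(C)cc2)c1CNC(C)(C)C`) gives 59900 nM; > 585000 nM (2 entries). Of these entries, one is a number and the other is a limit of the assay. Compound 2 (`CC(C)(C)NCc1c(C(=O)O)nn(-c2ccccc2)c1-c1ccccc1`) gives > 716000 nM, which is a limit of the assay and not a number. No single number is therefore available for compound 2, and its position is known only as that limit.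

The next structure is compound 3 (`Cc1ccc(-c2c(CNC(C)(C)C)c(C(=O)O)nn2-c2ccccc2)cc1`). Relative to compound 2, phenyl turns to 4-methylphenyl, para to a large group: methyl in place of hydrogen on an aromatic carbon.

For the measured compounds named here, no measured pair isolates this change, so the expectation rests on compound 2 and its limit of > 716000 nM. The expected size of an at least 1.1-fold lower number from compound 2 to compound 3 (0.07 log units; that floor lies within the scatter) is none beyond the scatter in this assay, with no direction favoured. Another limit instead of a number is also expected to be the likely outcome. For compound 3 the estimated value is 600000 nM, with an expected range from 150000 nM to 800000 nM.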

Compound 3, concentration for 50% growth inhibition: > 688000 nM
Compound 3 ended at the assay's limit; the forecaster's own chance of this, stated with the estimate: 75%; middle value at least 1.1-fold (0.05 log units) from the limit.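

The step from compound 2 to compound 3 cannot be read: in this assay each of the two compounds gives only a limit of the assay and not a number. The compounds shown leave open both the size and the direction of any effect of methyl in place of hydrogen on an aromatic carbon in this assay.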